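The compounds below may be only part of what the source reports. "The series", "measured", "known", "first", "only" and "open" are said of these compounds alone.

Compound 1 `Cc1ccc(NC(=O)c2cnn(-c3ccc(F)cc3)c2C)cc1` — in a functional assay with Homo sapiens as the target (a lower number here means a stronger inhibitor, a higher number a weaker inhibitor), compound 1 gives 540 nM
Compound 2 `Cc1c(C(=O)Nc2ccc(OC(F)(F)F)cc2)cnn1-c1ccc(F)cc1` — in this assay compound 2 gives 3400 nM

Among the compounds with values here, compound 1 holds the lowest of the two numbers in this assay; the only measured step from it, a 6.3-fold higher number from compound 1 to compound 2 (0.80 log units; beyond the scatter), runs in the weaker direction. Compound 3 `COc1cccc(NC(=O)c2cnn(-c3ccc(F)cc3)c2C)c1` differs from compound 1 as follows: 3-methoxyphenyl in place of 4-methylphenyl on an amide-type nitrogen. Within the data shown here, no measured pair shows this exact exchange. Among the measured compounds shown here, the one step on record, a 6.3-fold higher number from compound 1 to compound 2 (0.80 log units; beyond the scatter), concerns a different substituent at a different place on the same ring, and it bears on the question only loosely: it shows that altering this aryl group can cost potency in this assay, but the size of that loss need not carry over. A modest weakening is therefore the expected outcome, with wide uncertainty, and compound 3 is estimated at 1200 nM in this assay, within 400 nM to 4000 nM, which corresponds to an expected 2.2-fold higher number from compound 1 to compound 3 (0.35 log units; beyond the scatter).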

Compound 3, half-maximal inhibitory concentration: 3700 nM
Compound 3: the middle estimate sits 3.1-fold (0.49 log units) below what was measured, within the range that was stated.
By their numbers in this assay, from the lowest: compound 1; then compounds 2 and 3 (each within the scatter of the next).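

In this assay the exchange of 4-methylphenyl for 3-methoxyphenyl on the amide-type nitrogen gives a 6.9-fold higher number from compound 1 to compound 3 (0.84 log units; beyond the scatter) and so shows that a second change to this aryl group also raises the number. Together with a 6.3-fold higher number from compound 1 to compound 2 (0.80 log units; beyond the scatter) this means that neither replacement shown matches the 4-methylphenyl group of compound 1, and no compound shown goes against that. The new step changes the substituent and its numbered place on the ring in one exchange, so it cannot tell the effect of the methoxy group from the effect of its place.

No evidence on hand accounts for the higher number. Still open, as far as these compounds go, is whether a chlorine or an amine on this aryl ring would stay near compound 1 at 540 nM in this assay or rise as well.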